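Sulfonyl group exchange starting from compound 2

The compounds below may be only part of what the source reports. "The series", "measured", "known", "first", "only" and "open" are said of these compounds alone.

Among the measured compounds shown here, in an ADME assay on the whole organism (Rattus norvegicus, strain Sprague-Dawley) for pharmacokinetics, read by LC-MS, with a stated time of 30 min (a lower number here means that more of the compound stays in the plasma, a higher number that more of the compound sits outside the plasma), compound 1 (`N#Cc1ccc(O[C@H]2CN(S(=O)(=O)c3ccccc3C#N)C[C@@]2(O)CO)cc1F`) gives 0.9 L/kg and compound 2 (`N#Cc1ccc(O[C@H]2CN(S(=O)(=O)c3ccc(Cl)cn3)C[C@@]2(O)CO)cc1F`) gives 2.2 L/kg as the higher of the only two numbers so far. Compound 3 (`N#Cc1ccc(O[C@H]2CN(S(=O)(=O)c3ccc(Cl)cc3)C[C@@]2(O)CO)cc1F`) carries 4-chlorophenyl in place of 5-chloropyridin-2-yl on a sulfonyl sulfur and is not yet measured. For the measured compounds named here, only one measured step bears on this change: a 2.4-fold higher number from compound 1 to compound 2 (0.39 log units; beyond the scatter) for a modest exchange at the same place. Going by the values given here, that step replaced 2-cyanophenyl, so it does not isolate the present exchange, and no measured pair does. Chlorine stays in the group in this exchange, so only a small move is expected, with nothing beyond the scatter in this assay. The expected change is a 1.1-fold higher number from compound 2 to compound 3 (0.04 log units; within the scatter) in this working estimate. Compound 3 is estimated at 2.4 L/kg with an expected range from 1.3 L/kg to 4.5 L/kg for now.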

Compound 3, volume of distribution at steady state: 6 L/kg
For compound 3 the middle estimate is 2.5-fold (0.40 log units) below the measured one; measured number above the stated range.
By their numbers in this assay, from the lowest: compound 1; then compound 2; then compound 3.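

In this assay, the group on the sulfonyl sulfur responds to the exchange of a single ring atom: 4-chlorophenyl in place of 5-chloropyridin-2-yl gives a 2.7-fold higher number from compound 2 to compound 3 (0.44 log units; beyond the scatter), with the chlorine retained and the heavy-atom count of the group unchanged. The earlier step changed both the ring and its substituent, so it could not show that the ring nitrogen alone makes a difference beyond the scatter here. The two aryl groups furthest apart in this read-out are now 2-cyanophenyl and 4-chlorophenyl, with a 6.7-fold higher number from compound 1 to compound 3 (0.82 log units; beyond the scatter).

No supporting measurement accounts for these shifts. On these data alone, it remains open whether the same ring-atom exchange has a comparable effect with other substituents, and how an amine or a carboxylic acid in place of the chlorine would read in this assay.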